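Replacing the acid of compound 3 with a diol

The source may report more compounds than this note shows. Statements on the series, on what has been measured and on what is new or still open speak of the compounds shown alone.

Compound 3 `CCn1c(C(=O)NC(C)C(=O)O)ccc1C(CC)(CC)c1ccc(OCCC(O)(CC)CC)c(C)c1` gives 66 nM in an assay on cells for agonist activity at vitamin D3 receptor (Homo sapiens), with a stated time of 96 h (on this read-out higher numbers stand for an effect only at larger amounts of compound and lower numbers for an effect already at smaller amounts), the lowest of the three numbers shown. Compound 1 `CCn1c(C(=O)NCC#N)ccc1C(CC)(CC)c1ccc(OCCC(O)(CC)CC)c(C)c1` gives 1080 nM in this assay, and compound 2 `C#CCCOC(=O)c1ccc(C(CC)(CC)c2ccc(OCCC(O)(CC)CC)c(C)c2)n1CC` gives 6030 nM. The change to compound 4 `CCn1c(C(=O)NC(CO)CCO)ccc1C(CC)(CC)c1ccc(OCCC(O)(CC)CC)c(C)c1` is 3-hydroxy-1-(hydroxymethyl)propyl in place of 1-carboxyethyl on an amide-type nitrogen. Among the compounds with values here, two measured steps bear on it, since both remove or introduce the 1-carboxyethyl group: a 16-fold lower number from compound 1 to compound 3 (1.21 log units; beyond the scatter) and a 91-fold lower number from compound 2 to compound 3 (1.96 log units; beyond the scatter). Compound 4 keeps the amide but loses that group, so a rise in this assay is expected, a 7.6-fold higher number from compound 3 to compound 4 (0.88 log units; beyond the scatter), though probably not all the way back to the number of compound 1. For compound 4 the estimate is 500 nM, with a range from 100 nM to 2500 nM.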

Compound 4, half-maximal effective concentration: 2490 nM
Compound 4: the middle estimate sits 5.0-fold (0.70 log units) below what was measured; low and high end bracket the measured number.
By their numbers in this assay, from the lowest: compound 3; then compound 1; then compound 4; then compound 2.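

In this assay the 3-hydroxy-1-(hydroxymethyl)propyl group does not take over the role of the 1-carboxyethyl group on the amide-type nitrogen (a 38-fold higher number from compound 3 to compound 4 (1.58 log units; beyond the scatter)). It also stands above the cyanomethyl amide (a 2.3-fold higher number from compound 1 to compound 4 (0.36 log units; beyond the scatter)) and only modestly under the but-3-yn-1-yl ester (a 2.4-fold lower number from compound 2 to compound 4 (0.38 log units; beyond the scatter)). Among the compounds shown, keeping the amide is therefore not enough, as only compound 3 reaches a low number.

Nothing given here accounts for this gap. As far as these compounds go, whether a longer chain ending in a carboxylic acid, or an amine, on this nitrogen would keep the low number remains open.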